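A few compounds are considered here, and "the series" means these few. Any claim that something is new, unique, unknown or untested is made for them only; others in the source may bear on it.

In a physicochemical assay for solubility, read by HPLC, in phosphate buffer, measured as kinetic solubility, at pH 7.4 (on this read-out lower numbers stand for lower solubility and higher numbers for higher solubility), compound 2 `CN(C(=O)c1cc(-c2ccc(S(N)(=O)=O)cc2)n(-c2ccc(Cl)cc2)n1)C1CC(F)(F)C1` reads 30900 nM and compound 1 `NS(=O)(=O)c1ccc(-c2cc(C(=O)C3CCC3)nn2-c2ccc(Cl)cc2)cc1` reads 17200 nM, so the two stand level within the scatter. Compound 3 `NS(=O)(=O)c1ccc(-c2cc(C(=O)NN3CCCCC3)nn2-c2ccc(Cl)cc2)cc1` carries (piperidin-1-yl)amino in place of (3,3-difluorocyclobutyl)(methyl)amino on a carbonyl carbon. Among the measured compounds shown here, the only measured step, a 1.8-fold higher number from compound 1 to compound 2 (0.25 log units; within the scatter), changed a group on the same carbonyl carbon and stayed within the scatter, and no measured compound holds the entering group. No shift beyond the scatter is therefore expected in this assay, in either direction. The expected step is a 1.4-fold lower number from compound 2 to compound 3 (0.15 log units; within the scatter). Compound 3 is estimated at 22000 nM, with an expected range of 8000 nM to 60000 nM.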

Compound 3, solubility: 53700 nM
Estimate against measurement, compound 3: 2.4-fold (0.39 log units) below; the measured number falls inside the stated range.
By their numbers in this assay, from the lowest: compounds 1, 2 and 3 (each within the scatter of the next, the first and the last beyond it).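

In this assay the carbonyl carbon now shows a change beyond the scatter (a 3.1-fold higher number from compound 1 to compound 3 (0.49 log units; beyond the scatter)), with (piperidin-1-yl)amino in place of cyclobutyl. Against (3,3-difluorocyclobutyl)(methyl)amino, the same group gives a step within the scatter (a 1.7-fold higher number from compound 2 to compound 3 (0.24 log units; within the scatter)), so the two amino groups stand level here. Nothing available accounts for either step.

Open, as far as these compounds go, is whether the six-membered ring or the amide hydrogen of compound 3 matters more. A (morpholin-4-yl)amino or diethylamino group on the same carbonyl carbon would help separate the two.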